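Propyl on the Benzoyl Ring of a Kinase Inhibitor

The source may hold more compounds than are shown below. What is called first, only, known or untested is meant among the compounds shown, and "the series" means these compounds.

Compound 1 `COc1ccc(OCC(=O)Nc2cccc(NC(=O)c3ccc(N(C)C)cc3)c2)cc1F` gives 1820 nM in an assay on isolated protein for inhibition of Rho-associated protein kinase 1 (Homo sapiens), read by scintillation counting, radiometric assay and 33P incorporation, with a stated time of 40 min, in the presence of a further agent that is not named here; on this read-out higher numbers stand for weaker inhibition and lower numbers for stronger inhibition.
Compound 2 `O=C(COc1ccc2c(=O)ccoc2c1)Nc1cccc(NC(=O)c2ccccc2)c1` gives 120 nM in this assay.

Compound 2 holds the lower of the two numbers, and compound 1 stands beyond the scatter above it. Compound 3 `CCCc1ccc(C(=O)Nc2cccc(NC(=O)COc3ccc4c(=O)ccoc4c3)c2)cc1` differs from compound 2 in one place: propyl in place of hydrogen on an aromatic carbon. Going by the values given here, no measured pair isolates this change; compound 1 differs from compound 2 in more than one place, so its number says nothing about the propyl group. The author expects a step no larger than the scatter, in either direction. The estimate for compound 3 is 150 nM, with a range from 50 nM to 450 nM. The expected step is a 1.3-fold higher number from compound 2 to compound 3 (0.10 log units; within the scatter).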

Compound 3, half-maximal inhibitory concentration: 143 nM
Estimate against measurement, compound 3: 1.0-fold (0.02 log units) above; the range from low to high includes it.
By their numbers in this assay, from the lowest: compounds 2 and 3 (each within the scatter of the next); then compound 1.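

In this assay propyl in place of hydrogen gives a 1.2-fold higher number from compound 2 to compound 3 (0.08 log units; within the scatter) on the shared core. Going by these compounds alone, this is the first reading of the change, and it shows that an aromatic carbon para to a large group can carry propyl with the numbers of the two compounds within the scatter of each other. No measurement shown here accounts for this result.

The compounds shown leave open whether an amine, a carboxylic acid or a longer chain on this carbon would also fall within the scatter of compound 2. They also leave open whether propyl would give the same result on the core of compound 1.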